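The source may report more compounds than this note shows. Statements on the series, on what has been measured and on what is new or still open speak of the compounds shown alone.

Working notes on the series.

Going by the values given here, compound 3 `O=C(Nc1ccccc1O)C1CCc2ccccc2N1` gives 5610 nM in a functional assay on HCT-15 cells (Homo sapiens) for cytotoxicity, read by sulforhodamine B assay, with a stated time of 72 h (a higher number here means a weaker inhibitor of growth, a lower number a stronger inhibitor of growth), the second highest of the three numbers measured so far; compound 1 `O=C(Nc1ccccc1O)C1CCc2ccccc2N1C(=O)c1ccc(Cl)cc1` gives 20200 nM and compound 2 `O=C(Nc1ccccc1C(F)(F)F)C1CCc2ccccc2N1C(=O)c1cccc(Cl)c1` gives 797 nM. Among the compounds with values here, the one single-point step measured, a 3.6-fold lower number from compound 1 to compound 3 (0.56 log units; beyond the scatter), is modest but beyond the scatter. Compound 4 `O=C(Nc1ccccc1O)C1CCc2ccccc2N1C(=O)c1cccc(Cl)c1` differs from compound 3 by (3-chlorophenyl)carbonyl in place of hydrogen on a nitrogen on an aromatic ring in a ring. The step in this assay from compound 3 to compound 4 is therefore expected to run in the opposite direction to that from compound 1 to compound 3, a rise of similar size; compound 2 carries the same (3-chlorophenyl)carbonyl group but also a different aniline substituent, so its value alone cannot be taken as a guide. Compound 4 is expected at 13000 nM, with a range of 4000 nM to 40000 nM, an estimated step of a 2.3-fold higher number from compound 3 to compound 4 (0.36 log units; beyond the scatter).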

Compound 4, concentration for 50% growth inhibition: 23100 nM
Beside the measured number, compound 4's estimate is 1.8-fold (0.25 log units) below it; the measured number falls inside the stated range.
By their numbers in this assay, from the lowest: compound 2; then compound 3; then compounds 1 and 4 (each within the scatter of the next).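

In this assay the (3-chlorophenyl)carbonyl group on the nitrogen also goes with a weaker result, a 4.1-fold higher number from compound 3 to compound 4 (0.61 log units; beyond the scatter), so the rise is not confined to the 4-chlorophenyl group. Moving the chlorine makes no readable difference, a 1.1-fold higher number from compound 1 to compound 4 (0.06 log units; within the scatter). Going by these compounds alone, the largest step so far comes instead from hydroxy in place of trifluoromethyl on an aromatic carbon, a 29-fold higher number from compound 2 to compound 4 (1.46 log units; beyond the scatter).

No evidence on the cause of these steps is available. Open, going by these compounds, is how an amine or a methoxy group on that aromatic carbon would compare with hydroxy and trifluoromethyl.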